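The source may report more compounds than this note shows. Statements on the series, on what has been measured and on what is new or still open speak of the compounds shown alone.

Among the compounds with values here, compound 2 `CCN(Cc1ccccn1)c1ccc(C(=O)N2CCc3ccc(OS(N)(=O)=O)cc3C2)cc1` stands highest of the two numbers so far: in an assay on HEK293 cells for inhibition of Steryl-sulfatase (Homo sapiens), tested at 0.1 uM (a lower number here means a weaker effect, a higher number a stronger effect of the compound at the concentration tested), compound 2 gives 42.5%, while compound 1 `CCN(Cc1ccccn1)c1cccc(C(=O)N2CCc3ccc(OS(N)(=O)=O)cc3C2)c1` gives 6.5%, a gap beyond the usual scatter. The next compound is compound 3 `CCN(Cc1ccc(Br)cc1)c1ccc(C(=O)N2CCc3ccc(OS(N)(=O)=O)cc3C2)cc1`, not yet measured. The change from compound 2 is 4-bromophenyl in place of pyridin-2-yl on a saturated chain carbon bound to a nitrogen on an aromatic ring. Within the data shown here, no measured pair shows this change, so its direction is open; a step of modest size either way, or none beyond the scatter, is expected, a number 2.5 percentage points higher from compound 2 to compound 3 (within the scatter). Compound 3 is estimated at 45% in this assay, within a range from 20% to 70%.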

Compound 3, a percentage reported as inhibition, at one concentration (the size of the read-out at that concentration, not a potency): 78.2%
Estimate against measurement, compound 3: 33.2 percentage points below; the measured number lies above the stated range.
By their numbers in this assay, from the lowest: compound 1; then compound 2; then compound 3.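

Until compound 3, the group on the saturated chain carbon bound to a nitrogen on an aromatic ring had stayed pyridin-2-yl, so nothing showed whether it mattered. In this assay, 4-bromophenyl in its place gives a large change, a number 35.7 percentage points higher from compound 2 to compound 3 (beyond the scatter), so this position strongly affects the read-out. Nothing available explains why.

The compounds shown leave open whether the bromine or the carbon-only ring carries the step. An unsubstituted phenyl or a 4-chlorophenyl at this place would separate the two.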